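From Methyl to Methoxy at the Assay Limit

The source may report more compounds than this note shows. Statements on the series, on what has been measured and on what is new or still open speak of the compounds shown alone.

In a functional assay on HeLa cells (Homo sapiens) for cytotoxicity, read by MTT assay, with a stated time of 2 days (a higher number here means a weaker inhibitor, a lower number a stronger inhibitor), compound 1 `Cc1ccc2nc(-c3ccccc3N(C)C)[nH]c(=O)c2c1` gives 14000 nM, while compound 2 `CN(C)c1ccc2nc(-c3cccc4ccccc34)[nH]c(=O)c2c1` gives 50 nM. Compound 3 `Cc1cccc(-c2nc3ccc(C)cc3c(=O)[nH]2)c1` reaches only a limit (> 50000 nM). Compound 4 `COc1cccc(-c2nc3ccc(C)cc3c(=O)[nH]2)c1` differs from compound 3 by methoxy in place of methyl on an aromatic carbon, meta to a large group (methoxy in place of methyl on an aromatic carbon). Within the data shown here, no measured pair shows this change, so any forecast for this assay is tentative. The expectation rests on the limit of compound 3 (> 50000 nM). No step beyond the scatter is expected, and compound 4 should stay close to that limit. The expected step is an at least 1.1-fold lower number from compound 3 to compound 4 (0.04 log units; that floor lies within the scatter) and remains uncertain. Compound 4 is estimated at 45000 nM (expected range 12000 nM to 100000 nM).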

Compound 4, half-maximal inhibitory concentration: > 50000 nM
Compound 4: only a limit was reported; the forecaster's own chance of this, stated with the estimate: 60%; middle value at least 1.1-fold (0.04 log units) from the limit.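

Compound 3 and compound 4 both reach only a limit in this assay, so no step between them can be read: the limit of > 50000 nM in this assay, at which 2 of the 4 values shown sit.

On these data alone, what methoxy in place of methyl on an aromatic carbon does to the number in this assay stays open.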